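Methyl for Methoxy on a Sulfonamide-Bearing Core

A few compounds are considered here, and "the series" means these few. Any claim that something is new, unique, unknown or untested is made for them only; others in the source may bear on it.

Of the compounds shown here, two have been tested so far in an ADME assay on HCT-116 cells (Homo sapiens) for cytotoxicity, read by CellTiter-Glo, with a stated time of 72 h; on this read-out lower numbers stand for stronger inhibition and higher numbers for weaker inhibition. Compound 1, with the structure `CC1CCN(C2CCN(S(=O)(=O)c3ccc(Br)cc3OC(F)(F)F)CC2)CC1`, is recorded in this assay at > 5000 nM, and this is a limit of the assay rather than a measured number. Compound 2, with the structure `COc1ccc(-c2cccc(S(=O)(=O)N3CCC(N4CCC(C)CC4)CC3)c2)cc1`, is recorded in this assay at > 5000 nM, again a limit and not a number. Compound 2 therefore stands at the edge of what this assay can report, and it does not stand there alone: the limit of > 5000 nM in this assay, at which 2 of the 2 values shown sit. The untested compound 3, with the structure `Cc1ccc(-c2cccc(S(=O)(=O)N3CCC(N4CCC(C)CC4)CC3)c2)cc1`, differs from compound 2 in a single place: methyl in place of methoxy on an aromatic carbon. No pair of measured compounds differing in one place is available, so no measured step can be shown. The step expected in this assay is a step that the limit leaves unreadable from compound 2 to compound 3, which amounts to no change beyond the usual scatter. Compound 3 is accordingly estimated at 8000 nM, with a range from 3000 nM to 30000 nM, and it is expected most likely to be reported again only as a limit.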

Compound 3, half-maximal inhibitory concentration: > 5000 nM
Compound 3 was reported as a limit (the forecaster's own chance of this, stated with the estimate: 80%); the middle value does not contradict the limit.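

Compound 2 and compound 3 are each reported in this assay only as a limit, not as a number, so the change from methoxy to methyl yields no readable step between them: the limit of > 5000 nM in this assay, at which 3 of the 3 values shown sit.

The compounds shown leave open how far their true values lie beyond that limit, and whether any change to the shared core would bring a measurable value in this assay.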